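The compounds below may be only part of what the source reports. "The series", "measured", "known", "first", "only" and "open" are said of these compounds alone.

Measured in a functional assay on SK-BR-3 cells (Homo sapiens) for antiproliferative activity; a lower number here means a stronger inhibitor, a higher number a weaker inhibitor:
- compound 1 `CC(C)=CCc1cc(C(=O)Nc2cc3ccc(OCCCN(C)C(C)C)c(C)c3oc2=O)ccc1O`: 570 nM
- compound 2 `CC(C)=CCc1cc(C(=O)Nc2cc3ccc(OCCCNCCO)c(C)c3oc2=O)ccc1O`: 610 nM

Compound 2 stands level with compound 1, as their two values lie within the scatter of each other. Compound 3 `CC(C)=CCc1cc(C(=O)Nc2cc3ccc(OCCCN(C)c4ccccc4)c(C)c3oc2=O)ccc1O` keeps the shared core and differs from compound 2 only in the amino group at the end of the chain: methyl(phenyl)amino in place of (2-hydroxyethyl)amino on a saturated chain carbon, three bonds along the chain from an oxygen on an aromatic ring. In other words, methyl(phenyl)amino takes the place of (2-hydroxyethyl)amino on a saturated chain carbon, three bonds along the chain from an oxygen on an aromatic ring.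

Among the measured compounds shown here, one measured step bears on this change: a 1.1-fold higher number from compound 1 to compound 2 (0.03 log units; within the scatter). It exchanged one amino group for another at the same place and left this assay essentially unmoved. Neither compound 1 nor compound 2 carries an aromatic ring in this group, however, so the step is only a limited guide. With compound 2 at 610 nM, no step beyond the scatter is expected, though with a wide margin on either side. The estimated step is a 1.2-fold higher number from compound 2 to compound 3 (0.09 log units; within the scatter). For compound 3 the expected value is 750 nM, with an estimated range of 250 nM to 2200 nM.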

Compound 3, half-maximal inhibitory concentration: > 50000 nM
Compound 3: only a limit was reported; the forecaster's own chance of this, stated with the estimate: 5%; middle value at least 66-fold (1.82 log units) away from the limit.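

Exchanging one amino group for another at the end of the chain does not always leave the read-out unmoved: in this assay, methyl(phenyl)amino in place of (2-hydroxyethyl)amino gives an at least 81-fold higher number from compound 2 to compound 3 (1.91 log units; beyond the scatter). Among the compounds shown here, measured against the other earlier amino group, phenyl in place of isopropyl on an amine nitrogen gives an at least 87-fold higher number from compound 1 to compound 3 (1.94 log units; beyond the scatter), so the large step appears with either earlier compound as the reference, and the one group with a six-membered aromatic ring is the one that stands apart. The reading for compound 3 is a limit of the assay and not a number: the limit of > 50000 nM in this assay, at which 1 of the 3 values shown sits.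

These compounds do not separate the effect of an aromatic ring on the amine nitrogen from that of a ring as such, and a cyclohexyl or a benzyl group on that nitrogen would speak to this. As far as these compounds go, how a piperidine or a morpholine at the end of the 3-carbon propyl chain would read in this assay also stays open.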